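The source may hold more compounds than are shown below. What is called first, only, known or untested is meant among the compounds shown, and "the series" means these compounds.

In a functional assay on the whole organism for antagonist activity, with Mus musculus as the target, in the maximal electroshock model (a lower number here means that less compound is needed, a higher number that more compound is needed for the effect), compound 1 `COC(=O)NC1=NC(c2ccccc2)CN1C` gives 107 mg/kg and compound 2 `COC(=O)NC1=NC(c2cccc(Cl)c2)CN1C` gives 100 mg/kg as its dose, so compound 2 stands within the scatter of compound 1. Compound 3 `COC(=O)NC1=NC(c2cccc(OC)c2)CN1C` differs from compound 2 by methoxy in place of chloro on an aromatic carbon with methoxy in place of chloro on an aromatic carbon. For the measured compounds named here, the only measured step bearing on this is a 1.1-fold lower number from compound 1 to compound 2 (0.03 log units; within the scatter) for chloro in place of hydrogen on an aromatic carbon, and no measured compound carries methoxy. No step beyond the scatter is therefore expected in this assay in either direction. The estimated step is a 1.1-fold higher number from compound 2 to compound 3 (0.04 log units; within the scatter) on present data. Compound 3 is estimated at 110 mg/kg with 60 mg/kg to 200 mg/kg as the expected span.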

Compound 3, dose for half-maximal effect: 128 mg/kg
Beside the measured number, compound 3's estimate is 1.2-fold (0.07 log units) below it, and the stated range covers the measured number.
By their numbers in this assay, from the lowest: compounds 2, 1 and 3 (each within the scatter of the next).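

At this place on the aromatic ring, meta to a large group, methoxy adds a hydrogen-bond acceptor that chloro lacks, yet in this assay the dose stays within the scatter (a 1.3-fold higher number from compound 2 to compound 3 (0.11 log units; within the scatter); a 1.2-fold higher number from compound 1 to compound 3 (0.08 log units; within the scatter)). Hydrogen, chloro and methoxy at this place therefore cannot be told apart in this model. No available evidence speaks to the reason for this.

From the compounds shown here alone, whether an amine, a carboxylic acid or a longer chain such as butoxy at this place would move the dose beyond the scatter remains open. So does whether chloro and methoxy would behave alike elsewhere on the ring.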